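Swapping the Aryl Group on a Shared Core

The compounds below may be only part of what the source reports. "The series", "measured", "known", "first", "only" and "open" are said of these compounds alone.

Of the compounds shown here, two with a shared core have been measured in a functional assay on MCF7 cells (Homo sapiens) for inhibition, read by CCK-8 assay; on this read-out lower numbers stand for stronger inhibition and higher numbers for weaker inhibition. Compound 1 `Oc1ccccc1/C=N/c1nnc(SCc2nnc(-c3ccc(F)cc3)o2)s1` carries a 4-fluorophenyl group, and in this assay compound 1 gives 15600 nM. Compound 2 `COc1ccc(-c2nnc(CSc3nnc(/N=C/c4ccccc4O)s3)o2)cc1` carries a 4-methoxyphenyl group in its place, and compound 2 gives 4560 nM. Among the measured compounds shown here, that single exchange brought a 3.4-fold lower number from compound 1 to compound 2 (0.53 log units; beyond the scatter), so compound 2 stands at the lower of the two numbers, with compound 1 as its only neighbour.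

Compound 3 `O=[N+]([O-])c1cccc(-c2nnc(CSc3nnc(/N=C/c4ccccc4O)s3)o2)c1` has not yet been measured. Its change from compound 2 is 3-nitrophenyl in place of 4-methoxyphenyl on an aromatic carbon. For the measured compounds named here, no measured step involves a nitro group, so the only step that bears on this change is the earlier one, a 3.4-fold lower number from compound 1 to compound 2 (0.53 log units; beyond the scatter), which shows that exchanging the group on this phenyl ring can shift the number by a modest amount. Because the methoxy group that now leaves is the one whose arrival gave a 3.4-fold lower number from compound 1 to compound 2 (0.53 log units; beyond the scatter), compound 3 is expected to land at a somewhat higher number than compound 2, though with wide uncertainty. Compound 3 is expected to give 7000 nM, within 2500 nM to 20000 nM. The expected step is a 1.5-fold higher number from compound 2 to compound 3 (0.19 log units; within the scatter).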

Compound 3, half-maximal inhibitory concentration: 13900 nM
The estimate for compound 3 lay 2.0-fold (0.30 log units) below the measured number, within the range that was stated.
By their numbers in this assay, from the lowest: compound 2; then compounds 3 and 1 (each within the scatter of the next).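

In this assay the move to the 3-nitrophenyl group brings a 3.0-fold higher number from compound 2 to compound 3 (0.48 log units; beyond the scatter) and so gives up the improvement seen with 4-methoxyphenyl. The same group, set against 4-fluorophenyl, gives a 1.1-fold lower number from compound 1 to compound 3 (0.05 log units; within the scatter) and thus no readable difference, so the compound 1 and compound 3 pair cannot be told apart in this assay. This position on the five-membered aromatic ring therefore responds to the choice of aryl group, but among these three groups only 4-methoxyphenyl stands apart, and no supporting data are available to explain why.

The compounds shown cannot separate the identity of a group from its place on the phenyl ring, since the nitro group and the methoxy group are each seen at only one ring position, and 3-methoxyphenyl and 4-nitrophenyl would be the direct comparisons. On these data alone, it also remains open whether the better number belongs to methoxy alone or extends to relatives such as an ethoxy group, a longer alkoxy chain, a hydroxyl group or an amine at the same place.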